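Swapping a Naphthalene for a Propylurea on a Shared Core

The source may hold more compounds than are shown below. What is called first, only, known or untested is meant among the compounds shown, and "the series" means these compounds.

Of the compounds shown here, three sharing one core have been tested in a functional assay on A2780 cells (Homo sapiens) for antiproliferative activity, read by fluorescence, with a stated time of 72 h; a higher number here means a weaker inhibitor, a lower number a stronger inhibitor. Compound 1 `CC(C)(C)C(=O)N1Cc2c(NC(=O)c3cccnc3)n[nH]c2C1(C)C` gives 690 nM, compound 3 `CC(C)CC(=O)Nc1n[nH]c2c1CN(C(=O)C1CCN(C3CC3)CC1)C2(C)C` gives 320 nM, and compound 2 `CN1CCC(C(=O)N2Cc3c(NC(=O)c4ccc5ccccc5c4)n[nH]c3C2(C)C)CC1` gives 270 nM. Compound 2 thus has the lowest number of the three; its gap to compound 3 falls within the usual scatter, while its gap to compound 1 lies beyond it.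

Compound 4 `CCCNC(=O)Nc1n[nH]c2c1CN(C(=O)C1CCN(C)CC1)C2(C)C` differs from compound 2 in one place: propylamino in place of naphthalen-2-yl on a carbonyl carbon. A large two-ring aromatic group leaves and a short chain with one hydrogen-bond donor enters.

Compound 3 shows that a short alkyl group at the amide still gives 320 nM, so a modest loss is expected, with the step of a 3.3-fold higher number from compound 2 to compound 4 (0.52 log units; beyond the scatter). For compound 4 the expected value is 900 nM, in the range 300 nM to 3000 nM.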

Compound 4, half-maximal inhibitory concentration: 650 nM
Compound 4: the middle estimate sits 1.4-fold (0.14 log units) above what was measured; the measured number falls inside the stated range.
By their numbers in this assay, from the lowest: compounds 2 and 3 (each within the scatter of the next); then compounds 4 and 1 (each within the scatter of the next).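

On this carbonyl carbon, the large naphthalen-2-yl group is not required for activity. In this assay, propylamino in its place gives a 2.4-fold higher number from compound 2 to compound 4 (0.38 log units; beyond the scatter) and so costs only a modest amount, even though the incoming group has no ring and carries a hydrogen-bond donor that the naphthalen-2-yl group lacks. Nothing shown here explains the size of this step.

On these data alone, it remains open whether the nitrogen of propylamino matters or only the size of the group. A butyl chain or a single phenyl ring on the same carbonyl carbon would help separate the two.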